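The source may hold more compounds than are shown below. What is called first, only, known or untested is meant among the compounds shown, and "the series" means these compounds.

Three measured compounds set the stage. Compound 1 `CCN1CCN(c2cccc3c2C(=O)N([C@H](CCCNS(=O)(=O)c2cn(C)c(C)n2)c2ccc(OC)c(OC)c2)C3=O)CC1` is a sulfonamide on the chain, and in an assay on RMS13 cells for displacement of a labelled ligand from Urotensin-2 receptor (Homo sapiens), read by scintillation proximity assay (a lower number here means a stronger inhibitor, a higher number a weaker inhibitor), compound 1 gives 97 nM. Compound 2 `CCN1CCN(c2cccc3c2CN([C@H](CCCNC(=O)c2c(C)n[nH]c2C)c2ccc(OC)c(OC)c2)C3=O)CC1` carries an amide on that chain instead, and in this assay compound 2 gives 11 nM. Compound 3 `COc1ccc([C@@H](CCCN(C)S(=O)(=O)c2cccs2)N2Cc3c(cccc3N3CCN(C)CC3)C2=O)cc1OC` is read only as a limit of the assay, and in this assay compound 3 gives < 6 nM. Among the two plain numbers, compound 2 stands lowest, and the gap up to compound 1 lies beyond the scatter of repeated runs; the value of compound 3 is a limit and cannot be ranked against them.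

Compound 4 `CCN1CCN(c2cccc3c2CN([C@H](CCCNC(=O)c2cccs2)c2ccc(OC)c(OC)c2)C3=O)CC1` keeps the shared core of compound 2 and changes only the group on the amide: thiophen-2-yl in place of 3,5-dimethyl-1H-pyrazol-4-yl on a carbonyl carbon. Among the compounds with values here, no pair of measured compounds differs in just this way, so there is no measured step to lean on. The amide of compound 2 already sits low, and the thiophene-bearing compound 3 reaches the limit, so a modest move in the direction of stronger binding, or none beyond the scatter, is expected. The step from the measured value of compound 2 is expected to be a 1.2-fold lower number from compound 2 to compound 4 (0.09 log units; within the scatter). Compound 4 is estimated at 9 nM, with a likely range from 3 nM to 30 nM.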

Compound 4, inhibition constant: 18 nM
For compound 4 the middle estimate is 2.0-fold (0.30 log units) below the measured one, within the range that was stated.
By their numbers in this assay, from the lowest: compounds 2 and 4 (each within the scatter of the next); then compound 1. At a limit, below all of these: compound 3.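

In this assay, within the data shown here, replacing the group on the carbonyl carbon gives a 1.6-fold higher number from compound 2 to compound 4 (0.21 log units; within the scatter), the first step in this set in which only one group changes. The entering thiophen-2-yl has fewer heavy atoms than 3,5-dimethyl-1H-pyrazol-4-yl, carries sulfur where the leaving ring has nitrogen, and has no hydrogen-bond donor, yet the step stays within the scatter of repeated measurements. For this one pair, then, neither the hydrogen-bond donor nor the two methyl groups of the leaving ring turn out to be required for a value in this range, although a single swap cannot show whether that holds for other groups at this position.

Among these compounds, compound 3 is read only as a limit and differs from compound 4 in more than one place, so it provides no step at this position: the limit of < 6 nM in this assay, at which 1 of the 4 values shown sits. It remains open whether a phenyl ring, a cyclohexyl ring or a short chain ending in an amine on the same carbonyl carbon would keep the value in this range or move it beyond the scatter.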